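A few compounds are considered here, and "the series" means these few. Any claim that something is new, unique, unknown or untested is made for them only; others in the source may bear on it.

In a functional assay on HeLa cells (Homo sapiens) for cytotoxicity, read by MTT assay, with a stated time of 72 h (on this read-out higher numbers stand for weaker inhibition and lower numbers for stronger inhibition), compound 1 `COc1ccc(C(=O)c2cc(OC)c(OC)c(OC)c2)cc1NC(=O)/C=C/c1ccc(OC)c(OC)c1` gives 7800 nM, and compound 2 `COc1ccc(/C=C/C(=O)Nc2cc(C(=O)c3cc(OC)c(OC)c(OC)c3)cc(OC)c2OC)cc1OC` gives 2700 nM, the lowest of the two numbers shown. For the measured compounds named here, the only measured step, a 2.9-fold lower number from compound 1 to compound 2 (0.46 log units; beyond the scatter), concerns a methoxy on an aromatic carbon of the shared core, on the side that carries the amide nitrogen. Compound 3 `C#CCOc1cccc(/C=C/C(=O)Nc2cc(C(=O)c3cc(OC)c(OC)c(OC)c3)cc(OC)c2OC)c1` differs from compound 2 at a different place: 3-(propargyloxy)phenyl in place of 3,4-dimethoxyphenyl on a double-bonded chain carbon bound to a double-bonded chain carbon. Going by the values given here, no measured step touches this outer ring of the chain, so the numbers so far give no direction for the change, and the expectation rests on compound 2 alone. A step of a 1.1-fold higher number from compound 2 to compound 3 (0.05 log units; within the scatter) is therefore expected in this assay, a step not beyond the usual scatter, with wide uncertainty in both directions. Compound 3 is estimated at 3000 nM, within a range from 700 nM to 13000 nM.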

Compound 3, half-maximal inhibitory concentration: 7300 nM
For compound 3 the middle estimate is 2.4-fold (0.39 log units) below the measured one, and the stated range covers the measured number.
By their numbers in this assay, from the lowest: compound 2; then compounds 3 and 1 (each within the scatter of the next).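

The outer ring of the chain is not a silent position in this assay: putting 3-(propargyloxy)phenyl in place of 3,4-dimethoxyphenyl gives a 2.7-fold higher number from compound 2 to compound 3 (0.43 log units; beyond the scatter), a modest weakening. The earlier step showed only that a methoxy on the shared core moves the number, whereas this one shows that the ring at the far end of the chain moves it as well, and by a similar size. Nothing measured here speaks to why the number rises.

This swap removes both methoxy groups and adds the propargyloxy group in one move, so the compounds shown cannot separate those changes. From the compounds shown here alone, how a single methoxy, an amine or a carboxylic acid on this outer ring would read in this assay remains open.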